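Lengthening the butyl chain of compound 3

The compounds below may be only part of what the source reports. "The series", "measured", "known", "first", "only" and "open" are said of these compounds alone.

In a functional assay for inhibition, with Rattus norvegicus as the target (on this read-out higher numbers stand for an effect only at larger amounts of compound and lower numbers for an effect already at smaller amounts), compound 1 `CSCC[C@H](NC(=O)c1ccc(CNCCC2CCCCC2)cc1-c1ccccc1C)C(=O)O` gives 200 nM. Compound 2 `CC[C@H](CC1CCCCC1)NCc1ccc(C(=O)N[C@@H](CCSC)C(=O)O)c(-c2ccccc2C)c1`, with ethyl in place of hydrogen, is reported only as a limit, > 1000 nM. Compound 3 `CCCC[C@H](CC1CCCCC1)NCc1ccc(C(=O)N[C@@H](CCSC)C(=O)O)c(-c2ccccc2C)c1`, with butyl there instead, gives 4.3 nM, the lowest number among the three. Compound 4 `CSCC[C@H](NC(=O)c1ccc(CN[C@H](CCCC(C)C)CC2CCCCC2)cc1-c1ccccc1C)C(=O)O` differs from compound 3 by isopropyl in place of methyl on a saturated chain carbon, four bonds along the chain from an amine nitrogen, which is isopropyl in place of methyl, turning butyl into 4-methylpentyl. Among the compounds with values here, three measured steps bear on this: an at least 5.0-fold higher number from compound 1 to compound 2 (0.69 log units; beyond the scatter), a 47-fold lower number from compound 1 to compound 3 (1.67 log units; beyond the scatter) and an at least 230-fold lower number from compound 2 to compound 3 (2.36 log units; beyond the scatter). All are beyond the scatter, yet none extends past butyl, so no step beyond the scatter is expected in this assay. The expected step is a 1.4-fold higher number from compound 3 to compound 4 (0.14 log units; within the scatter). For compound 4 the estimate is 6 nM, within an expected range of 1.5 nM to 40 nM.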

Compound 4, half-maximal effective concentration: 52 nM
Beside the measured number, compound 4's estimate is 8.7-fold (0.94 log units) below it, and the stated range ends below it.
By their numbers in this assay, from the lowest: compound 3; then compound 4; then compound 1. At a limit, above all of these: compound 2.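

In this assay, the chain at this position does not keep its gain when butyl becomes 4-methylpentyl, which gives a 12-fold higher number from compound 3 to compound 4 (1.08 log units; beyond the scatter), yet much of the gain over hydrogen remains, with a 3.8-fold lower number from compound 1 to compound 4 (0.59 log units; beyond the scatter) and an at least 19-fold lower number from compound 2 to compound 4 (1.28 log units; beyond the scatter). Even so, isobutyl in place of hydrogen in that last step still separates compound 4 clearly from the ethyl of compound 2. Compound 2 stands only as a limit: the limit of > 1000 nM in this assay, at which 1 of the 4 values shown sits. The compounds shown leave open whether the rise from compound 3 follows from added length or from branching. A straight pentyl or hexyl chain on the same carbon would separate the two.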